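A few compounds are considered here, and "the series" means these few. Any claim that something is new, unique, unknown or untested is made for them only; others in the source may bear on it.

Among the measured compounds shown here, compound 1, with the structure `CCOC(=O)c1cccc(-c2ccc(OCC)cc2)c1`, is the stronger of the two compounds measured so far in an assay on COS-7 cells for inhibition of patatin-like phospholipase domain-containing protein 2 (Mus musculus) (a lower number here means a stronger inhibitor, a higher number a weaker inhibitor), where compound 1 gives 50000 nM. For the measured compounds named here, its only measured neighbour is compound 2, `CCOC(=O)c1cccc(-c2ccc(C)cc2)c1`, which in this assay gives 140000 nM; that is a 2.8-fold higher number from compound 1 to compound 2 (0.45 log units; beyond the scatter).

Compound 3, `CCOc1ccc(-c2cccc(C(=O)NC)c2)cc1`, has not been measured. It differs from compound 1 in one place: methylamino in place of ethoxy on a carbonyl carbon. The ethoxycarbonyl group of compound 1 becomes a methylcarbamoyl group in compound 3.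

Going by the values given here, no measured step touches this place. Among the compounds with values here, the one step known, from ethoxy to methyl on an aromatic carbon, sits on the other part of the shared core and says nothing about a change on the carbonyl carbon. With nothing to lean on, the expectation for compound 3 is a number near that of compound 1, with any shift likely staying within the usual scatter, so that the expected step reads a 1.2-fold higher number from compound 1 to compound 3 (0.08 log units; within the scatter).

The estimate for compound 3 in this assay is therefore 60000 nM, with a range from 15000 nM to 200000 nM.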

Compound 3, half-maximal inhibitory concentration: > 200000 nM
Compound 3: only a limit was reported (the forecaster's own chance of this, stated with the estimate: 30%); middle value at least 3.3-fold (0.52 log units) from the limit.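

Among the compounds shown here, the carbonyl carbon, which the earlier compounds left untouched, turns out not to be a neutral place in this assay: replacing ethoxy with methylamino there gives an at least 4.0-fold higher number from compound 1 to compound 3 (0.60 log units; beyond the scatter). From the compounds shown here alone, the reading for compound 3, > 200000 nM, is a limit of the assay and not a number, so this step marks only the smallest change that fits the data, and its true size remains unknown. Both single changes shown from compound 1, one at each of two different places on the shared core, now raise the number beyond the scatter, and no compound here is a stronger inhibitor than compound 1.

The compounds shown do not tell whether the loss follows from leaving the ethoxycarbonyl group in general or from the methylcarbamoyl group in particular, and a carboxylic acid or a longer chain on the carbonyl carbon, such as propoxy, would bear on that question. Going by these compounds, it also remains open whether dimethylamino on the same carbonyl carbon, which has no amide hydrogen, would give a reading closer to that of compound 1 or of compound 3.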